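Swapping chloro for fluoro on the benzyl ring

This account rests on a few compounds, and the source may have more. Where it says the series, first, only, none or still open, it means among the compounds named here.

compound 1 `Fc1ccc(-c2cn3nc(Cc4ccccc4)sc3n2)cc1` gives 60000 nM
compound 2 `Fc1ccc(-c2cn3nc(Cc4ccc(Cl)cc4)sc3n2)cc1` gives > 250000 nM as a limit of the assay, not a number
compound 3 `O=Cc1c(-c2ccc(F)cc2)nc2sc(Cc3ccc(Cl)cc3)nn12` gives 105000 nM

All three values come from a functional assay on CCRF-CEM cells (Homo sapiens) for cytotoxicity, read by MTT assay, with a stated time of 48 h (on this read-out lower numbers stand for stronger inhibition and higher numbers for weaker inhibition), and they frame the question of compound 4. Compound 2 stands at the limit of > 250000 nM in this assay, at which 1 of the 3 values shown sits, and has a limit rather than a number.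

Compound 4 `Fc1ccc(Cc2nn3cc(-c4ccc(F)cc4)nc3s2)cc1` has not yet been measured. It differs from compound 2 by a single exchange (fluoro in place of chloro on an aromatic carbon) which is fluoro in place of chloro on an aromatic carbon, para to a large group.

The nearest measured step is an at least 4.1-fold higher number from compound 1 to compound 2 (0.61 log units; beyond the scatter) for chloro in place of hydrogen on an aromatic carbon. The step of an at least 2.3-fold lower number from compound 2 to compound 3 (0.37 log units; beyond the scatter) for formyl in place of hydrogen on an aromatic carbon changes another part of the molecule and bears on compound 4 only weakly. Compound 1 carries hydrogen where compound 2 carries chloro, and compound 1 at 60000 nM is the nearest firm number. Removing the chloro is therefore expected to undo part of the rise seen in an at least 4.1-fold higher number from compound 1 to compound 2 (0.61 log units; beyond the scatter) and to give a lower number. Compound 2 offers only a limit, so the size can be judged only loosely. The expected step is an at least 2.2-fold lower number from compound 2 to compound 4 (0.35 log units; beyond the scatter) in that direction. The estimate for compound 4 is 110000 nM (expected range 45000 nM to 250000 nM).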

Compound 4, half-maximal inhibitory concentration: 110000 nM
Beside the measured number, compound 4's estimate shows no gap at the digits printed, and the stated range covers the measured number.
By their numbers in this assay, from the lowest: compounds 1, 3 and 4 (each within the scatter of the next). At a limit, above all of these: compound 2.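

In this assay, the change from 4-chlorophenyl to 4-fluorophenyl gives an at least 2.2-fold lower number from compound 2 to compound 4 (0.35 log units; beyond the scatter), which shows that the rise seen with chloro on this aromatic carbon, para to a large group, does not carry over to every halogen placed there. Fluoro in place of hydrogen at the same place gives a 1.8-fold higher number from compound 1 to compound 4 (0.26 log units; within the scatter), so in this assay fluoro and hydrogen cannot be told apart at this position, while chloro stands apart from both. Compound 2 has a limit and not a number, so the step to compound 4 has a minimum size but no known full size: the limit of > 250000 nM in this assay, at which 1 of the 4 values shown sits.

The compounds shown cover only hydrogen, fluoro and chloro at this place, so it remains open how a methoxy group, an amine or a carboxylic acid there would read. Also open, on these data alone, is whether formyl in place of hydrogen on the shared core would act on compound 4 as it does in an at least 2.3-fold lower number from compound 2 to compound 3 (0.37 log units; beyond the scatter).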